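Halogen swap on the fused ring of compound 1

The compounds below may be only part of what the source reports. "The series", "measured", "known", "first", "only" and "open" are said of these compounds alone.

Three compounds of this series have numbers in a functional assay on the whole organism with Rattus norvegicus as the target, at a dose of 20 mg/kg by the oral route; on this read-out higher numbers stand for more inhibition at the one dose given (going by the name of the read-out) and lower numbers for less inhibition. Compound 1 `NC(=O)/C=C1\CCc2c(F)cccc21` gives 34% in this assay. Compound 2 `CNC(=O)/C=C1\CCc2ccc(Br)cc21` gives 53%, and compound 3 `NC(=O)/C=C1\CCc2cc(F)cc(F)c21` gives 55%. Compound 1 thus stands lowest of the three measured compounds; its gap to compound 2 and its gap to compound 3 both lie beyond the usual scatter of repeated measurements. Among the measured compounds shown here, no two of the measured compounds differ in only one place, so no single step between measured compounds can be read off for this assay.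

Compound 4 `NC(=O)/C=C1\CCc2c(Cl)cccc21` has not yet been measured. It differs from compound 1 as follows: chloro in place of fluoro on an aromatic carbon. For the measured compounds named here, none of the measured compounds exchanges one substituent for another at an otherwise unchanged place, so there is no measured step of this kind to lean on. The step from compound 1 to compound 4 is expected to be small, a number 6 percentage points higher from compound 1 to compound 4 (within the scatter), and is not expected to exceed the scatter in this assay. Compound 4 is expected to give about 40% in this assay, with an estimated range from 24% to 58%.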

Compound 4, a percentage reported as inhibition, in the whole organism at one dose (the size of the read-out at that dose, not a potency): 58%
The estimate for compound 4 lay 18 percentage points below the measured number; low and high end bracket the measured number.
By their numbers in this assay, from the lowest: compound 1; then compounds 2, 3 and 4 (each within the scatter of the next).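

In this assay, among the compounds shown here, chloro in place of fluoro on an aromatic carbon, ortho to a fused ring and meta to a fused ring, gives a number 24 percentage points higher from compound 1 to compound 4 (beyond the scatter) and is the first single-place step that can be read. The read-out at this place therefore depends on which of these two halogens it carries, even though one heavy atom is exchanged for one heavy atom and the rest of the core of compound 1 stays the same. The compounds shown come with no measurement that would explain this step.

A bromo, methyl or methoxy group at this same place would show whether the rise continues beyond chloro or is particular to it, and the unsubstituted core would show whether fluoro or chloro moves the number away from the parent at all. On these data alone, whether the exchange gives a similar step on an N-methyl amide also stays open, as does whether the step reflects potency, since the read-out comes from one oral dose.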